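Swapping (3-methoxyphenyl)amino for dipropylamino

The source may hold more compounds than are shown below. What is called first, only, known or untested is meant among the compounds shown, and "the series" means these compounds.

Values from a functional assay on HeLa cells (Homo sapiens) for inhibition, read by sulforhodamine B assay; a higher number here means a weaker inhibitor, a lower number a stronger inhibitor
Compound 1 `O=C1C(NC2CCCC2)=CC(=O)c2c1nc1n2[C@H]2OC[C@@H](O)[C@H]2OC1` reads > 16000 nM as a limit
Compound 2 `COc1cccc(NC2=CC(=O)c3c(nc4n3[C@H]3OC[C@@H](O)[C@H]3OC4)C2=O)c1` reads > 8000 nM as a limit

Compound 2 has no exact number on this scale: its > 8000 nM is a limit of the assay. Compound 3 `CCCN(CCC)C1=CC(=O)c2c(nc3n2[C@H]2OC[C@@H](O)[C@H]2OC3)C1=O` keeps the shared core and carries dipropylamino in place of (3-methoxyphenyl)amino on a double-bonded ring carbon here. Within the data shown here, the one measured step that bears on this is a step that the two limits leave unreadable from compound 1 to compound 2 and it has no readable size, as both of its ends are limits. It therefore points to no direction for the new change. With compound 2 at > 8000 nM as a limit, compound 3 is expected to remain a weak inhibitor in this assay and may well read as a limit too. The expected step is a step that the limit leaves unreadable from compound 2 to compound 3 and this estimate has no firm direction. For compound 3 the estimated value is 10000 nM within an expected range from 3000 nM to 32000 nM in this assay overall.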

Compound 3, half-maximal inhibitory concentration: > 16000 nM
Compound 3: a limit, no number (the forecaster's own chance of this, stated with the estimate: 60%); at least 1.6-fold (0.20 log units) between middle value and limit.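

In this assay, compound 3 reads > 16000 nM, which is a limit. Compound 1 and compound 2 also carry limits, so neither step to compound 3 can be read. The compounds shown leave open how the cyclopentylamino, (3-methoxyphenyl)amino and dipropylamino groups rank against one another on the shared core.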